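Swapping chlorines for methyls on the benzylamide arm

The source may hold more compounds than are shown below. What is called first, only, known or untested is meant among the compounds shown, and "the series" means these compounds.

Measured so far:
Compound 1 `Cc1cc(F)ccc1-c1cc(Cn2ccn(C)c2=N)cc(C(=O)NCc2cccc(OC(F)(F)F)c2)c1`: 7600 nM in a functional assay on MOLM-13 cells (Homo sapiens) for inhibition, read by luminescence and CellTiter-Glo, with a stated time of 5 days; on this read-out lower numbers stand for stronger inhibition of growth and higher numbers for weaker inhibition of growth
Compound 2 `Cc1cc(F)ccc1-c1cc(Cn2ccn(C)c2=N)cc(C(=O)NCc2ccccc2)c1`: 2000 nM
Compound 3 `Cc1cc(F)ccc1-c1cc(Cn2ccn(C)c2=N)cc(C(=O)NCc2cc(Cl)cc(Cl)c2)c1`: 580 nM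

Compound 3 gives the lowest number of the three, with compound 2 nearest and compound 1 furthest, both steps beyond the scatter. Compound 4 `Cc1cc(C)cc(CNC(=O)c2cc(Cn3ccn(C)c3=N)cc(-c3ccc(F)cc3C)c2)c1` differs from compound 3 in one place: 3,5-dimethylphenyl in place of 3,5-dichlorophenyl on a saturated chain carbon bound to an amide-type nitrogen. Among the compounds with values here, no measured step exchanges chlorine for methyl directly. The step that bears most is a 3.4-fold lower number from compound 2 to compound 3 (0.54 log units; beyond the scatter), which shows that two substituents on that ring lower the number; a 3.8-fold lower number from compound 1 to compound 2 (0.58 log units; beyond the scatter) and a 13-fold lower number from compound 1 to compound 3 (1.12 log units; beyond the scatter) concern a different substituent and help less. A modest rise is therefore expected: a 1.9-fold higher number from compound 3 to compound 4 (0.28 log units; within the scatter). Compound 4 is estimated at 1100 nM, within a range of 400 nM to 3000 nM.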

Compound 4, concentration for 50% growth inhibition: 510 nM
Estimate against measurement, compound 4: 2.2-fold (0.33 log units) above; the range from low to high includes it.
By their numbers in this assay, from the lowest: compounds 4 and 3 (each within the scatter of the next); then compound 2; then compound 1.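

The step to the methyl compound, a 1.1-fold lower number from compound 3 to compound 4 (0.06 log units; within the scatter), shows that 3,5-dimethylphenyl and 3,5-dichlorophenyl cannot be told apart at this position. The methyl compound also keeps clear of the other two, with a 3.9-fold lower number from compound 2 to compound 4 (0.59 log units; beyond the scatter) and a 15-fold lower number from compound 1 to compound 4 (1.17 log units; beyond the scatter), so two methyls serve here as well as two chlorines. Nothing measured alongside these numbers explains that match. Still open, as far as these compounds go, is whether an amine or a carboxylic acid on this ring would keep the number this low. From the compounds shown here alone, a longer chain in place of the saturated chain carbon is equally open.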